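A few compounds are considered here, and "the series" means these few. Any claim that something is new, unique, unknown or untested is made for them only; others in the source may bear on it.

Measured so far:
compound 1, `CN1C(=S)[C@@H](NC(=O)c2nc(Cc3ccccc3)n(CCCO)n2)COc2ccccc21`: 209 nM
compound 2, `CN1C(=S)[C@@H](NC(=O)c2nc(Cc3ccccc3)n(C3CCCC3)n2)COc2ccccc21`: 3530 nM

Among the compounds with values here, in a functional assay on HT-29 cells (Homo sapiens) for inhibition, read by luminescence and CellTiter-Glo, with a stated time of 24 h (on this read-out higher numbers stand for an effect only at larger amounts of compound and lower numbers for an effect already at smaller amounts), compound 1 gives 209 nM, while compound 2 gives 3530 nM, the highest of the two numbers; the single step between them, a 17-fold higher number from compound 1 to compound 2 (1.23 log units; beyond the scatter), set cyclopentyl in place of 3-hydroxypropyl on an aromatic nitrogen. Compound 3, `CN1C(=S)[C@@H](NC(=O)c2nc(Cc3ccccc3)n(C3CCNCC3)n2)COc2ccccc21`, changes the same site again: piperidin-4-yl in place of cyclopentyl on an aromatic nitrogen. The group that leaves is a ring of carbon only; the group that enters brings one hydrogen-bond donor and one hydrogen-bond acceptor, as the 3-hydroxypropyl of compound 1 did. Within the data shown here, that one step is the only guide, and it was large. The expectation for compound 3 is therefore a move back toward the number of compound 1, probably not all the way: the estimated step is a 4.4-fold lower number from compound 2 to compound 3 (0.64 log units; beyond the scatter). In this assay compound 3 is expected near 800 nM, within 250 nM to 2500 nM.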

Compound 3, half-maximal effective concentration: 1000 nM
Compound 3: the middle estimate sits 1.3-fold (0.10 log units) below what was measured, and the stated range covers the measured number.
By their numbers in this assay, from the lowest: compound 1; then compound 3; then compound 2.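

Swapping cyclopentyl for piperidin-4-yl on this aromatic nitrogen gives a 3.5-fold lower number from compound 2 to compound 3 (0.55 log units; beyond the scatter) in this assay, so a ring at this position can be kept while the number falls, once that ring carries a nitrogen. Matching counts of hydrogen-bond donors and acceptors do not make two groups equal here: piperidin-4-yl and 3-hydroxypropyl have the same counts, yet the change between them gives a 4.8-fold higher number from compound 1 to compound 3 (0.68 log units; beyond the scatter). No measurement at hand explains either step.

The compounds shown leave open whether the gap between compound 1 and compound 3 follows from the ring, from the hydroxyl in place of the amine, or from both. A 3-aminopropyl chain would hold the chain and change only the hydroxyl, while a tetrahydropyran-4-yl ring would hold the ring and put an oxygen in place of the nitrogen.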